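From dimethylamino to methoxy on a shared core

The source may hold more compounds than are shown below. What is called first, only, known or untested is meant among the compounds shown, and "the series" means these compounds.

Compound 1 `CCCS(=O)(=O)Nc1ccc(F)c(C(=O)Nc2cnc3[nH]nc(C)c3c2)c1F` and compound 2 `CCCS(=O)(=O)Nc1ccc(F)c(C(=O)Nc2cnc3[nH]nc(N(C)C)c3c2)c1F` share one core and differ in one place. Within the data shown here, in a physicochemical assay for solubility, read by HPLC, in phosphate buffer, with a stated time of 24 h, at pH 7.4 (on this read-out lower numbers stand for lower solubility and higher numbers for higher solubility), compound 1 gives 740 ug/mL and compound 2 gives 450 ug/mL as its number, so compound 2 cannot be told apart from its only neighbour. Compound 3 `CCCS(=O)(=O)Nc1ccc(F)c(C(=O)Nc2cnc3[nH]nc(OC)c3c2)c1F` carries methoxy in place of dimethylamino on an aromatic carbon. Among the measured compounds shown here, the one measured step at this place, a 1.6-fold lower number from compound 1 to compound 2 (0.22 log units; within the scatter) with dimethylamino in place of methyl, is small, so nothing beyond the scatter is expected in this assay for compound 3. The estimated step is a 1.1-fold higher number from compound 2 to compound 3 (0.05 log units; within the scatter) by this expectation. For compound 3 the estimated value is 500 ug/mL within an expected range of 220 ug/mL to 1000 ug/mL in this measurement.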

Compound 3, solubility: 9 ug/mL
The estimate for compound 3 lay 56-fold (1.74 log units) above the measured number; measured number below the stated range.
By their numbers in this assay, from the lowest: compound 3; then compounds 2 and 1 (each within the scatter of the next).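

In this assay this position proves far from indifferent, although methyl and dimethylamino could not be told apart there. Methoxy gives a 50-fold lower number from compound 2 to compound 3 (1.70 log units; beyond the scatter) and an 82-fold lower number from compound 1 to compound 3 (1.91 log units; beyond the scatter), both beyond the scatter. The group on this aromatic carbon can therefore matter greatly, even when the groups exchanged have the same counts of hydrogen-bond donors and acceptors.

Nothing at hand says why the number falls so far. From the compounds shown here alone, it also remains open whether ethoxy or a hydroxyl group at this place would give a low number like methoxy or a high one like methyl.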